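The compounds below may be only part of what the source reports. "The series", "measured", "known", "first", "only" and "open" are said of these compounds alone.

Working notes on the thiosemicarbazone series.

Three compounds have a number in a functional assay on MCF7 cells (Homo sapiens) for cytotoxicity, read by MTT assay, with a stated time of 72 h, tested at 3 uM; on this read-out higher numbers stand for more inhibition of growth at the one concentration tested and lower numbers for less inhibition of growth. Compound 1 `N/C(=N\NC(=S)N1CCOCC1)c1ccccn1` gives 44.5%. Compound 2 `Cc1ccnc(/C(N)=N/NC(=S)N2CCSCC2)c1` gives 33.8%. Compound 3 `N/C(=N\NC(=S)N1CCSCC1)c1ccccn1` gives 29%, the lowest of the three; its nearest neighbour is compound 2, within the scatter, and its furthest is compound 1, beyond the scatter. The two one-place steps show a number 15.5 percentage points lower from compound 1 to compound 3 (beyond the scatter) and a number 4.8 percentage points lower from compound 2 to compound 3 (within the scatter).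

Compound 4 `N/C(=N\NC(=S)N1CCCCC1)c1ccccn1` differs from compound 3 by piperidin-1-yl in place of thiomorpholin-4-yl on a thiocarbonyl carbon. Among the compounds with values here, the only measured step at the thiocarbonyl carbon is the one from compound 1 to compound 3, which was modest and beyond the scatter; it says that a change of ring partner at this position can move the number, but nothing has been measured for piperidin-1-yl itself, so the direction is open. Within the data shown here, a step of the same order in either direction is thus expected, centred slightly above compound 3 because the one change at this position, a number 15.5 percentage points lower from compound 1 to compound 3 (beyond the scatter), lowered the number and its reversal is as likely as not. Compound 4 is estimated at 34%, with a range from 16% to 52%, which is an expected step of a number 5 percentage points higher from compound 3 to compound 4 (within the scatter).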

Compound 4, percent growth inhibition at one concentration: 38.6%
The estimate for compound 4 lay 4.6 percentage points below the measured number; the range from low to high includes it.
By their numbers in this assay, from the lowest: compounds 3, 2, 4 and 1 (each within the scatter of the next, the first and the last beyond it).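

In this assay, the piperidin-1-yl ring of compound 4 cannot be separated from either of the other two rings on the thiocarbonyl carbon: the steps read a number 9.6 percentage points higher from compound 3 to compound 4 (within the scatter) and a number 5.9 percentage points lower from compound 1 to compound 4 (within the scatter). Within the data shown here, the only step beyond the scatter at this position therefore remains a number 15.5 percentage points lower from compound 1 to compound 3 (beyond the scatter), and piperidin-1-yl, with one hetero atom in its ring, does not side clearly with either morpholin-4-yl or thiomorpholin-4-yl. No evidence at hand bears on a cause for these numbers.

From the compounds shown here alone, it remains open whether a piperazin-1-yl ring or an open-chain dimethylamino group on the thiocarbonyl carbon would stay within this same band. Also open, going by these compounds, is whether a methyl group on the aromatic carbon would give a step beyond the scatter alongside morpholin-4-yl or piperidin-1-yl.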